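From 4,4-difluoropiperidin-1-yl to piperidin-1-yl on compound 1

This account rests on a few compounds, and the source may have more. Where it says the series, first, only, none or still open, it means among the compounds named here.

Among the compounds with values here, in a functional assay on MCF7 cells (Homo sapiens) for inhibition, read by resazurin assay, with a stated time of 24 h (on this read-out lower numbers stand for stronger inhibition and higher numbers for weaker inhibition), compound 1 `O=C1Nc2c(C(F)(F)F)cccc2C1(c1ccc(O)cc1)N1CCC(F)(F)CC1` gives 35 nM, the only actual number available in this small series. Compound 2 `O=C1Nc2c(C(F)(F)F)cccc2[C@@]1(c1ccc(O)cc1)C1CCC(F)(F)CC1` is reported as > 1000 nM, which is a limit of the assay and not a number. Within the data shown here, compound 1 therefore stands as the one compound with a measured potency, and no ranking beyond that can be drawn from the two results.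

The next compound to be tested is compound 3 `O=C1Nc2c(C(F)(F)F)cccc2C1(c1ccc(O)cc1)N1CCCCC1`, which keeps the core of compound 1 but carries piperidin-1-yl in place of 4,4-difluoropiperidin-1-yl on a saturated ring carbon. Among the measured compounds shown here, no measured pair of compounds differing in one place is available to size this change, so the expectation is anchored only on compound 1 at 35 nM. In this assay, a small move towards weaker inhibition is expected, one that may not clear the usual scatter, and the estimated size is a 1.7-fold higher number from compound 1 to compound 3 (0.23 log units; within the scatter). For compound 3 the estimated value is 60 nM, with an expected range from 15 nM to 250 nM.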

Compound 3, half-maximal inhibitory concentration: > 1000000 nM
Compound 3: only a limit was reported; the forecaster's own chance of this, stated with the estimate: 8%; middle value at least 16000-fold (4.22 log units) from the limit.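

In this assay, within the data shown here, replacing 4,4-difluoropiperidin-1-yl with piperidin-1-yl on the saturated ring carbon gives the first step that can be sized at this position: an at least 28000-fold higher number from compound 1 to compound 3 (4.45 log units; beyond the scatter). For compound 3, the reported > 1000000 nM is a limit of the assay and not a number. The two structures differ only in the two fluorine atoms of the 4,4-difluoropiperidin-1-yl group, yet within this pair the plain piperidin-1-yl group does not keep the inhibition seen with compound 1, so a change this small in atom count at this position is enough to separate a measured potency from a limit, a far larger effect than the small shift that could have been mistaken for scatter.

The compounds shown give no measurement that explains why the two fluorine atoms matter so much here. They also leave open whether the effect needs both fluorine atoms or only some substitution on this ring, a question that 4-fluoropiperidin-1-yl, 4-hydroxypiperidin-1-yl or morpholin-4-yl at the same place would address in this assay.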